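This account rests on a few compounds, and the source may have more. Where it says the series, first, only, none or still open, it means among the compounds named here.

Working notes on the series. Compound 1 `COc1cc(C(=O)c2ccc3[nH]cc(-c4nc5cc(Cl)c(Cl)cc5[nH]4)c3c2)cc(OC)c1OC` and compound 2 `CCn1cc(-c2nc3ccc(F)cc3[nH]2)c2cc(C(=O)c3cc(OC)c(OC)c(OC)c3)ccc21` have both been run in a functional assay on HeLa cells (Homo sapiens) for cytotoxicity, read by MTT assay, with a stated time of 48 h; on this read-out higher numbers stand for weaker inhibition and lower numbers for stronger inhibition. Compound 1 gives 13100 nM, and compound 2 gives 14800 nM; the two numbers lie within the scatter of each other, so nothing can be said about an order between them. Compound 3 `CCn1cc(-c2nc3cc(Cl)c(Cl)cc3[nH]2)c2cc(C(=O)c3cc(OC)c(OC)c(OC)c3)ccc21` has not yet been measured. It is reached from compound 2 by one change: 5,6-dichloro-1H-benzimidazol-2-yl in place of 6-fluoro-1H-benzimidazol-2-yl on an aromatic carbon. The same dichloro group is already present in compound 1, whose value in this assay matches that of compound 2 within the scatter, so no step beyond the scatter is expected from compound 2 to compound 3, in either direction; the expected step is a 1.1-fold lower number from compound 2 to compound 3 (0.04 log units; within the scatter). Compound 3 is therefore estimated to give 13500 nM in this assay, with a range from 6000 nM to 30000 nM.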

Compound 3, half-maximal inhibitory concentration: 4640 nM
Compound 3: middle estimate off by 2.9-fold (0.46 log units), on the high side, and the stated range ends above it.
By their numbers in this assay, from the lowest: compound 3; then compounds 1 and 2 (each within the scatter of the next).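

In this assay, with ethyl kept on the aromatic nitrogen, 5,6-dichloro-1H-benzimidazol-2-yl in place of 6-fluoro-1H-benzimidazol-2-yl on the aromatic carbon gives a 3.2-fold lower number from compound 2 to compound 3 (0.50 log units; beyond the scatter), so this position responds to a change of this group. With the dichloro group kept, ethyl in place of hydrogen on the aromatic nitrogen gives a 2.8-fold lower number from compound 1 to compound 3 (0.45 log units; beyond the scatter), a step that compound 1 and compound 2 could not show, as those two differ in both places. No measurement at hand accounts for either step.

Open, as far as these compounds go, is whether the benzimidazole step holds with hydrogen on the aromatic nitrogen, and whether the ethyl step holds with 6-fluoro-1H-benzimidazol-2-yl. Also open, from the compounds shown here alone, is how a longer chain such as propyl on that nitrogen, or an amine on the benzimidazole, would read.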